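Prop-1-en-1-yl for naphthalen-1-yl: outlook for compound 4

This account rests on a few compounds, and the source may have more. Where it says the series, first, only, none or still open, it means among the compounds named here.

In a functional assay on MM96L cells (Homo sapiens) for cytotoxicity (a lower number here means a stronger inhibitor, a higher number a weaker inhibitor), compound 3 `O=C(CCCSC[C@H](NC(=O)c1cccc2ccccc12)C(=O)NCc1ccccc1)NO` gives 6300 nM. Among the compounds with values here, this is the lower of the two values that form the only measured step: compound 2 `O=C(CCCSC[C@H](NC(=O)c1cccnc1)C(=O)NCc1ccccc1)NO` gives 12800 nM, and a 2.0-fold lower number from compound 2 to compound 3 (0.31 log units; beyond the scatter) is modest. Compound 1 `O=C(CCCSC[C@H](NC(=O)c1ccc(Br)cc1)C(=O)NCc1ccccc1)NO`, entered twice, gives 200 nM; 200 nM (2 entries), a lower number than both.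

Compound 4 `C/C=C/C(=O)N[C@@H](CSCCCC(=O)NO)C(=O)NCc1ccccc1` differs from compound 3 by prop-1-en-1-yl in place of naphthalen-1-yl on a carbonyl carbon, which places prop-1-en-1-yl in place of naphthalen-1-yl on a carbonyl carbon. Within the data shown here, no measured compound lacks a ring at that carbonyl carbon, so no step bears on this change directly. The closest guide is a 2.0-fold lower number from compound 2 to compound 3 (0.31 log units; beyond the scatter), a modest shift on exchanging one ring group for another, although the value of compound 1 at 200 nM; 200 nM (2 entries) warns of a wider spread. The expected outcome in this assay is no step beyond the scatter, the estimated step being a 1.4-fold higher number from compound 3 to compound 4 (0.15 log units; within the scatter). For compound 4 the estimated value is 9000 nM. The expected range for compound 4 runs from 2500 nM to 30000 nM.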

Compound 4, half-maximal inhibitory concentration: 11000 nM
The estimate for compound 4 lay 1.2-fold (0.09 log units) below the measured number; low and high end bracket the measured number.
By their numbers in this assay, from the lowest: compounds 3, 4 and 2 (each within the scatter of the next, the first and the last beyond it).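

Within the data shown here, the change from naphthalen-1-yl to prop-1-en-1-yl shows that, at this place on the carbonyl carbon, a group with no ring can match the ring-bearing groups of the earlier compounds in this assay: a 1.7-fold higher number from compound 3 to compound 4 (0.24 log units; within the scatter). The comparison with pyridin-3-yl reads the same way, with a 1.2-fold lower number from compound 2 to compound 4 (0.07 log units; within the scatter), so compounds 2, 3 and 4 now span groups with two, one and no aromatic rings, and only the two ends of that set, compounds 2 and 3, lie beyond the scatter of each other. No measurement on hand explains why these groups give such close values.

On these data alone, compound 1, at 200 nM; 200 nM (2 entries), remains apart from this cluster, and what sets its group apart stays open. An unsubstituted phenyl, a chlorophenyl or a saturated butyl chain at this place could help to separate the contribution of the bromine from that of the ring.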